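Adding a Bromine to the Benzyl Group of Compound 3

A few compounds are considered here, and "the series" means these few. Any claim that something is new, unique, unknown or untested is made for them only; others in the source may bear on it.

Three compounds share one core and differ only in the group attached to the ring oxygen. Compound 1 `CCOc1ccc2cc(C(=O)NCCO)c(=O)oc2c1` and compound 2 `CCCOc1ccc2cc(C(=O)NCCO)c(=O)oc2c1` carry short saturated chains there. In a functional assay on HCT-116 cells (Homo sapiens) for cytotoxicity, read by MTT assay, with a stated time of 72 h (on this read-out lower numbers stand for stronger inhibition and higher numbers for weaker inhibition), compound 1 reaches only the assay's limit, > 100000 nM. Compound 2 likewise gives only a limit, > 100000 nM. For the measured compounds named here, compound 3 `O=C(NCCO)c1cc2ccc(OCc3ccccc3)cc2oc1=O`, which carries a benzyl group, gives 18700 nM, the only true number among the three. The steps of an at least 5.3-fold lower number from compound 1 to compound 3 (0.72 log units; beyond the scatter) and an at least 5.3-fold lower number from compound 2 to compound 3 (0.72 log units; beyond the scatter) are both read against (the limit of > 100000 nM in this assay, at which 2 of the 3 values shown sit), so their full size stays hidden.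

Compound 4 `O=C(NCCO)c1cc2ccc(OCc3cccc(Br)c3)cc2oc1=O` differs from compound 3 by bromo in place of hydrogen on an aromatic carbon. Going by the values given here, no measured step alters the benzyl ring itself; the two steps that exist only show that exchanging a chain for that ring matters a great deal. A single bromo is a much smaller alteration than those, so the expected step of a 1.6-fold lower number from compound 3 to compound 4 (0.19 log units; within the scatter) is small and its direction uncertain. Compound 4 is therefore estimated at 12000 nM, with a plausible range from 4000 nM to 40000 nM.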

Compound 4, half-maximal inhibitory concentration: 30800 nM
The estimate for compound 4 lay 2.6-fold (0.41 log units) below the measured number, and the stated range covers the measured number.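

In this assay, the only change shown on the benzyl ring itself gives a 1.6-fold higher number from compound 3 to compound 4 (0.22 log units; within the scatter), so the 3-bromobenzyl and benzyl groups cannot be told apart at this position. The lower numbers seen against the short saturated chains persist with the bromo group in place: an at least 3.2-fold lower number from compound 1 to compound 4 (0.51 log units; beyond the scatter) and an at least 3.2-fold lower number from compound 2 to compound 4 (0.51 log units; beyond the scatter) both lie beyond the scatter. These two steps give only minimum sizes, and their full size stays hidden: the limit of > 100000 nM in this assay, at which 2 of the 4 values shown sit.

As far as these compounds go, whether bromo on a different carbon of the same ring would give a number distinguishable from that of compound 3 remains open. From the compounds shown here alone, it is also open whether a different group at this ring position, such as an amine or a carboxylic acid, would move the number beyond the scatter.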